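Swapping the pyridyl amide cap for a dibromophenyl ring

This account rests on a few compounds, and the source may have more. Where it says the series, first, only, none or still open, it means among the compounds named here.

Compound 1 `O=C(COc1ccc2cc(/C=C3/SC(=O)NC3=O)ccc2c1)Nc1cccc(F)n1` and compound 2 `Cc1cccc(NC(=O)COc2ccc3cc(/C=C4/SC(=O)NC4=O)ccc3c2)n1` share the same core and differ only in the group carried on the amide-type nitrogen. In an assay on isolated protein for inhibition of histone deacetylase 4 (Homo sapiens), with a stated time of 1 h (a lower number here means a stronger inhibitor, a higher number a weaker inhibitor), compound 1 gives 840 nM, and compound 2 gives 1100 nM. The step of a 1.3-fold higher number from compound 1 to compound 2 (0.12 log units; within the scatter) lies within the scatter, so compound 2 holds the highest of the two numbers without being separable from compound 1.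

Compound 3 `O=C(COc1ccc2cc(/C=C3/SC(=O)NC3=O)ccc2c1)Nc1ccc(Br)c(Br)c1` introduces (3,4-dibromophenyl in place of 6-methylpyridin-2-yl on an amide-type nitrogen). Among the measured compounds shown here, only one measured step bears on this change, a 1.3-fold higher number from compound 1 to compound 2 (0.12 log units; within the scatter), and it exchanged a single substituent on the aromatic ring rather than the ring itself. Because the step of a 1.3-fold higher number from compound 1 to compound 2 (0.12 log units; within the scatter) stayed within the scatter, the available data give no sign that the amide cap drives large shifts, but they also say nothing about replacing a heteroaromatic ring with a carbon-only one. No step beyond the scatter is therefore expected, with a wide margin.

On this basis compound 3 is estimated at 900 nM in this assay. The range for compound 3 is expected to run from 300 nM to 3000 nM. The estimated step is a 1.2-fold lower number from compound 2 to compound 3 (0.09 log units; within the scatter).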

Compound 3, half-maximal inhibitory concentration: 4900 nM
Beside the measured number, compound 3's estimate is 5.4-fold (0.74 log units) below it; the whole stated range lies below it.
By their numbers in this assay, from the lowest: compounds 1 and 2 (each within the scatter of the next); then compound 3.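

Among the compounds shown here, replacing the pyridine cap on the amide-type nitrogen with 3,4-dibromophenyl gives the first change at this position that lies beyond the scatter in this assay: a 4.5-fold higher number from compound 2 to compound 3 (0.65 log units; beyond the scatter), and likewise a 5.8-fold higher number from compound 1 to compound 3 (0.77 log units; beyond the scatter). The earlier exchange of fluoro for methyl on the pyridine ring, a 1.3-fold higher number from compound 1 to compound 2 (0.12 log units; within the scatter), could not be separated from the scatter, whereas both pyridine compounds are stronger inhibitors than the dibromophenyl compound 3, which shows that this position can respond to a change of the whole cap, although the step here is modest. No measurement is available to explain the shift.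

The step removes the ring nitrogen and adds the two bromines in a single change, leaving open which of these accounts for the weaker inhibition, and a phenyl ring with no bromine or with a single bromine would be needed to separate them. Also open, on these data alone, is how the number would respond to a cap bearing an amine or a carboxylic acid, or to a pyridine ring carrying bromine.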